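A few compounds are considered here, and "the series" means these few. Any claim that something is new, unique, unknown or untested is made for them only; others in the source may bear on it.

Among the two compounds measured in an assay on HEK293 cells for displacement of a labelled ligand from 5-hydroxytryptamine receptor 7 (Rattus norvegicus), with a stated time of 60 min (a lower number here means a stronger inhibitor, a higher number a weaker inhibitor), compound 2 `Fc1ccc(-c2cn(Cc3ccccc3)c3c2CNCC3)cc1` gives the lowest number, 45 nM. Compound 1 `Clc1cccc(-c2cn(Cc3ccccc3)c3c2CNCC3)c1` gives 10000 nM in this assay. For the measured compounds named here, the only measured step, a 220-fold lower number from compound 1 to compound 2 (2.35 log units; beyond the scatter), is large, but it swaps one group for another and also moves it, so it does not test the hydroxy itself. Compound 3 `Oc1ccc(-c2cn(Cc3ccccc3)c3c2CNCC3)cc1` differs from compound 2 by hydroxy in place of fluoro on an aromatic carbon. Going by the values given here, with no step bearing directly on this exchange, the direction is uncertain; the expected step is a 2.4-fold higher number from compound 2 to compound 3 (0.39 log units; beyond the scatter), a modest weakening. Compound 3 is estimated at 110 nM, within 20 nM to 600 nM.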

Compound 3, inhibition constant: 10000 nM
Beside the measured number, compound 3's estimate is 91-fold (1.96 log units) below it, and the stated range ends below it.
By their numbers in this assay, from the lowest: compound 2; then compounds 1 and 3 (each within the scatter of the next).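

In this assay, hydroxy in place of fluoro, a swap of one heavy atom para to a large group, gives a 220-fold higher number from compound 2 to compound 3 (2.35 log units; beyond the scatter) and so removes the low number of compound 2. Putting 4-hydroxyphenyl in place of 3-chlorophenyl gives no change at the digits printed from compound 1 to compound 3 (within the scatter) for the remaining pair, so among these three compounds only the 4-fluorophenyl one has a low number. Nothing available here explains this sensitivity. Still open, going by these compounds, is how a methoxy group or an amine would read at this same place, and whether chloro at this place would behave like fluoro or like hydroxy.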